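The compounds below may be only part of what the source reports. "The series", "measured", "known", "first", "only" and "open" are said of these compounds alone.

Working notes on the series. Compound 1 `O=C(O)CCc1ccc(NCc2ccc(Cl)cc2)cc1` is measured in a functional assay for agonist activity at Free fatty acid receptor 1 (Homo sapiens) (on this read-out higher numbers stand for an effect only at larger amounts of compound and lower numbers for an effect already at smaller amounts), at 1000 nM. Within the three numbers available, compound 1 stands second highest: the nearest neighbour is compound 3 `O=C(O)CCc1ccc(NCc2ccc(-c3ccccc3)cc2)cc1`, which in this assay gives 251 nM, and the furthest is compound 2 `CC(C(=O)O)c1ccc(NCc2cccc(Oc3ccccc3)c2)cc1`, which gives 16600 nM. Compound 2 differs from compound 1 in more than one place, so its two values are only compared and no single change is read from them.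

For the measured compounds named here, the one single-place step available is a 4.0-fold lower number from compound 1 to compound 3 (0.60 log units; beyond the scatter), a modest gain on replacing the chloro with a phenyl.

Compound 4 `O=C(O)CCc1ccc(NCc2ccc(Cl)c(Cl)c2)cc1` is not yet measured. It differs from compound 1 by chloro in place of hydrogen on an aromatic carbon: the new chloro sits on an aromatic carbon of a six-membered aromatic ring of carbon only, ortho to a chloro group and meta to a large group. Going by the values given here, no measured step adds a second chloro to this ring, so the step from compound 1 to compound 3 bears on it only loosely, showing that the ring tolerates a larger group at the existing chloro position. For compound 4 a small step is expected, a 1.4-fold lower number from compound 1 to compound 4 (0.15 log units; within the scatter), not clearly beyond the scatter. The estimate for compound 4 is therefore 700 nM, with a range from 250 nM to 2000 nM.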

Compound 4, half-maximal effective concentration: 251 nM
The estimate for compound 4 lay 2.8-fold (0.45 log units) above the measured number; measured number inside the range.
By their numbers in this assay, from the lowest: compounds 3 and 4 (each within the scatter of the next); then compound 1; then compound 2.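

The added chloro, ortho to a chloro group and meta to a large group, opens a second place on this ring where a change moves the number, giving a 4.0-fold lower number from compound 1 to compound 4 (0.60 log units; beyond the scatter) in this assay. For the compounds shown here, until now the only single-place information on the ring came from the existing chloro position, where the swap to phenyl gave a 4.0-fold lower number from compound 1 to compound 3 (0.60 log units; beyond the scatter), so the two steps show that both places respond and that a chloro of 1 heavy atom at the new place gives a step of the same printed size as the phenyl at the old one. No measurement on hand accounts for the gain at this position.

The compounds shown leave open whether the step belongs to chloro itself or would also appear with a fluoro, a methyl or a methoxy group at the same place. They also leave open whether this chloro and the phenyl of compound 3 would add up when carried together on the core of compound 1, or whether the two steps overlap.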